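Swapping Nitrophenyl for Dimethoxyphenyl on a Weak Scaffold

A few compounds are considered here, and "the series" means these few. Any claim that something is new, unique, unknown or untested is made for them only; others in the source may bear on it.

Compound 1, `O=C(/C=C/c1ccc([N+](=O)[O-])cc1)Nc1cc(Sc2ncn[nH]2)c(O)c2ccccc12`: > 100000 nM in a functional assay on PC-3 cells (Homo sapiens) for antiproliferative activity, read by MTT assay, with a stated time of 48 h (on this read-out higher numbers stand for weaker inhibition and lower numbers for stronger inhibition), which is a limit of the assay.
Compound 2, `Cc1nnc(Sc2cc(NC(=O)c3ccc(Cl)cc3)c3ccccc3c2O)s1`: 49500 nM in this assay.
Compound 3, `O=C(Nc1cc(Sc2ncn[nH]2)c(O)c2ccccc12)c1ccc2ccccc2c1`: > 100000 nM in this assay, which is a limit of the assay.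

Compound 1 has no measured number in this assay, only a limit; the same is true of compound 3, so that the limit of > 100000 nM in this assay, at which 2 of the 3 values shown sit, is where two of the three values sit. Within the data shown here, compound 2 is the one compound here with a real number, and it, too, inhibits growth only weakly. No pair among these three differs in a single place, so no measured step can be followed within the set.

Compound 4, `COc1ccc(/C=C/C(=O)Nc2cc(Sc3ncn[nH]3)c(O)c3ccccc23)cc1OC`, is made from compound 1 by one change: 3,4-dimethoxyphenyl in place of 4-nitrophenyl on a double-bonded chain carbon bound to a double-bonded chain carbon. Nothing in the measured compounds shows what this change does, because none of them carries a 3,4-dimethoxyphenyl on a double-bonded chain carbon. With compound 1 already at the limit and compound 3 sharing that fate, the expectation for compound 4 is that the step from compound 1 to compound 4 is a number no higher from compound 1 to compound 4 (the limit leaves the size open), that is, none beyond the scatter, with a real chance that only a limit is reported again. Compound 4 is therefore estimated at 100000 nM, in the range 30000 nM to 300000 nM.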

Compound 4, half-maximal inhibitory concentration: > 100000 nM
Compound 4: no number, only a limit; the forecaster's own chance of this, stated with the estimate: 65%; the middle value sits exactly at the limit.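

Among these compounds, compound 1 and compound 4 each give only a limit of the assay, not a number, and no step between them can be read. Compound 4 joins compound 1 and compound 3 at the same limit: the limit of > 100000 nM in this assay, at which 3 of the 4 values shown sit.

As far as these compounds go, whether 3,4-dimethoxyphenyl in place of 4-nitrophenyl changes growth inhibition at all in this assay remains open.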